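The source may hold more compounds than are shown below. What is called first, only, known or untested is meant among the compounds shown, and "the series" means these compounds.

Three compounds share one core and were compared in a functional assay on A549 cells (Homo sapiens) for inhibition, read by CCK-8 assay, with a stated time of 72 h, tested at 2 uM; on this read-out higher numbers stand for more inhibition of growth at the one concentration tested and lower numbers for less inhibition of growth. Compound 1, `Cc1ccc(SCc2ccc(/C=C/C(=O)Nc3ccccc3N)cc2)cc1`, gives 43.4%. Compound 2, `COc1ccc(SCc2ccc(/C=C/C(=O)Nc3ccccc3N)cc2)cc1OC`, gives 65.5%. Compound 3, `Nc1ccccc1NC(=O)/C=C/c1ccc(CSc2ccc(F)cc2)cc1`, gives 51.2%, the second highest of the three numbers: its gap to compound 1 is within the scatter, while the step of a number 14.3 percentage points lower from compound 2 to compound 3 (beyond the scatter) is beyond it.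

Compound 4, `Nc1ccccc1NC(=O)/C=C/c1ccc(CSc2ccc(Cl)cc2)cc1`, differs from compound 3 by chloro in place of fluoro on an aromatic carbon. Within the data shown here, no measured step swaps one of these two groups for the other. Among the measured compounds shown here, the closest comparison, a number 7.8 percentage points higher from compound 1 to compound 3 (within the scatter), stayed within the scatter, and the one step beyond it, a number 22.1 percentage points higher from compound 1 to compound 2 (beyond the scatter), changed a much larger group. A small change of this kind is therefore expected to move this assay by no more than the scatter.

Compound 4 is accordingly estimated at 53%, with a range from 40% to 66%, an expected step of a number 1.8 percentage points higher from compound 3 to compound 4 (within the scatter).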

Compound 4, percent growth inhibition at one concentration: 55.3%
For compound 4 the middle estimate is 2.3 percentage points below the measured one; measured number inside the range.
By their numbers in this assay, from the lowest: compounds 1, 3 and 4 (each within the scatter of the next, the first and the last beyond it); then compound 2.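

In this assay, chloro and fluoro at this position on the aromatic ring cannot be told apart (a number 4.1 percentage points higher from compound 3 to compound 4 (within the scatter)). Chloro does separate from methyl (a number 11.9 percentage points higher from compound 1 to compound 4 (beyond the scatter)), which fluoro did not, while 3,4-dimethoxyphenyl stays ahead of 4-chlorophenyl (a number 10.2 percentage points lower from compound 2 to compound 4 (beyond the scatter)). No measurement at hand offers an explanation for these differences.

The compounds shown leave open how a bromo group, an amine or a carboxylic acid would read at this position. They also leave open whether compound 2 needs both of its methoxy groups to reach its number.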